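An Aliphatic Acid Chain Replaces the Fluorophenyl Amide

This account rests on a few compounds, and the source may have more. Where it says the series, first, only, none or still open, it means among the compounds named here.

Compound 1 `O=C(Nc1cc(Nc2ccc(Cl)cc2)ncn1)c1ccc(F)cc1`: 1610 nM
Compound 2 `CCOC(=O)CCCC(=O)Nc1cc(Nc2cccc(Cl)c2)ncn1`: > 10000 nM

In an assay for inhibition of Receptor tyrosine-protein kinase erbB-3 variant L858R (Homo sapiens), read by mobility shift assay, with a stated time of 10 min (a higher number here means a weaker inhibitor, a lower number a stronger inhibitor), compound 1 gives 1610 nM. Compound 2 reaches the limit of the assay, > 10000 nM, and no number is known for it. Compound 1 thus holds the only number shown; the other value is a limit (the limit of > 10000 nM in this assay, at which 1 of the 2 values shown sits). Compound 3 `O=C(O)CCC(=O)Nc1cc(Nc2ccc(Cl)cc2)ncn1` has not yet been measured. It differs from compound 1 in one place: 2-carboxyethyl in place of 4-fluorophenyl on a carbonyl carbon. No step between two measured compounds that differ in a single place is shown, so the size of this change rests on no measured pair. Compound 2 also carries a chain amide and sits at the limit, but it differs from compound 1 in its aniline as well, so its value alone does not fix the size of the change. A step from compound 1 to compound 3 of a 3.7-fold higher number from compound 1 to compound 3 (0.57 log units; beyond the scatter) towards weaker inhibition is expected. Compound 3 is expected to give about 6000 nM, between 2000 nM and 20000 nM.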

Compound 3, half-maximal inhibitory concentration: 825 nM
Beside the measured number, compound 3's estimate is 7.3-fold (0.86 log units) above it; the measured number lies below the stated range.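

The exchange of 4-fluorophenyl for 2-carboxyethyl on this carbonyl carbon gives a step that can be read in this assay: a 2.0-fold lower number from compound 1 to compound 3 (0.29 log units; within the scatter). Inhibition therefore remains measurable with no six-membered aromatic ring at this place and with a chain ending in a carboxylic acid, so the ring of compound 1 is not needed for a value of this size. Nothing measured here explains why the two groups read alike.

On these data alone, whether a plain propyl chain, a longer chain or a chain ending in an amine would read the same on the core of compound 3 remains open. Also open, as far as these compounds go, is whether the carboxylic acid itself matters, a question that the methyl ester of compound 3 would address.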